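Ethoxy to methoxy on the quinoline carboxylic acid amide

The source may report more compounds than this note shows. Statements on the series, on what has been measured and on what is new or still open speak of the compounds shown alone.

Three compounds of the series are measured. Compound 1 `Cc1ccc2nc(C(=O)Nc3c(F)cc(-c4cccc(F)c4)cc3F)c(C)c(O)c2c1` gives 2.34% in a functional assay on Hep 3B2 cells (Homo sapiens) for antiproliferative activity, read by MTT assay, with a stated time of 24 h, tested at 0.14 ug/mL; on this read-out lower numbers stand for a weaker effect and higher numbers for a stronger effect at the one concentration tested. Compound 2 `CCc1ccc2nc(C(=O)Nc3c(F)cc(-c4cccc(F)c4)cc3F)c(C)c(O)c2c1` gives 11.2% in this assay. Compound 3 `CCOc1ccc2nc(C(=O)Nc3c(F)cc(-c4cccc(F)c4)cc3F)c(C)c(C(=O)O)c2c1` gives 2.06% in this assay. The change hydrogen in place of methyl on a saturated chain carbon bound to an aromatic carbon produces a number 8.9 percentage points lower from compound 2 to compound 1 (within the scatter). The difference between the core of compound 2 and the core of compound 3 is not broken down here.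

Compound 4 `COc1ccc2nc(C(=O)Nc3c(F)cc(-c4cccc(F)c4)cc3F)c(C)c(C(=O)O)c2c1` is not yet measured; it differs from compound 3 by hydrogen in place of methyl on a saturated chain carbon bound to an oxygen on an aromatic ring. This is the same kind of change as that from compound 2 to compound 1, but the place differs: there the carbon is bound to an aromatic carbon, here to an oxygen on an aromatic ring. A step of similar size, within the scatter, is expected from compound 3 to compound 4 in this assay, resting on a number 8.9 percentage points lower from compound 2 to compound 1 (within the scatter); the expected step is a number 0.9 percentage points higher from compound 3 to compound 4 (within the scatter). Compound 4 is estimated at 3%, between -5% and 12%.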

Compound 4, a percentage reported as inhibition, at one concentration (the size of the read-out at that concentration, not a potency): 0.02%
Compound 4: the middle estimate sits 3 percentage points above what was measured; low and high end bracket the measured number.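

In this assay ethoxy to methoxy gives a number 2 percentage points lower from compound 3 to compound 4 (within the scatter) on the core of compound 3. For the compounds shown here, this does not show that the change has a shared effect across the two cores: both steps are small, only two cores are compared, and a real difference between them could stay hidden in the scatter. As far as these compounds go, the change carries from one core to the other without a detectable difference: the same change on two cores in this assay, a number 8.9 percentage points lower (within the scatter) from compound 2 to compound 1 and a number 2 percentage points lower (within the scatter) from compound 3 to compound 4, 6.8 percentage points apart, within the scatter of two such steps

Still open, from the compounds shown here alone, is what a longer chain such as propoxy, or an amine, would give in place of ethoxy on the core of compound 3. Also open, going by these compounds, is whether any step between these compounds would emerge at a concentration other than the one tested.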